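One Added Hydroxy on Compound 2

The source may report more compounds than this note shows. Statements on the series, on what has been measured and on what is new or still open speak of the compounds shown alone.

Of the compounds shown here, two have been measured in an ADME assay for permeability, using PAMPA, with a stated time of 10 h, tested at 100 ug/mL; a higher number here means that the compound crosses the layer faster, a lower number that the compound crosses the layer more slowly. Compound 1 `Oc1ccc2oc(-c3ccc(O)c4ncccc34)cc2c1` gives 15.5 10^-6 cm/s, while compound 2 `Oc1c(Cl)cc(-c2cc3ccccc3o2)c2cccnc12` gives 2.6 10^-6 cm/s, the lower of the two numbers and a gap beyond the usual scatter. Compound 3 `Oc1ccc2oc(-c3cc(Cl)c(O)c4ncccc34)cc2c1` is compound 2 with one change: hydroxy in place of hydrogen on an aromatic carbon. For the measured compounds named here, the two measured compounds differ in more than one place, so no measured step shows this change alone. Compound 3 shares the new hydroxy with compound 1, which gives 15.5 10^-6 cm/s, but it otherwise keeps the structure of compound 2, which gives 2.6 10^-6 cm/s. This leaves the direction open, with only a loose guide from two values. The expected 1.5-fold higher number from compound 2 to compound 3 (0.19 log units; within the scatter) in this assay stays within the scatter, so no clear change is expected. Compound 3 is estimated at 4 10^-6 cm/s, with an expected range of 1.2 10^-6 cm/s to 13 10^-6 cm/s.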

Compound 3, apparent permeability: 21.4 10^-6 cm/s
Beside the measured number, compound 3's estimate is 5.4-fold (0.73 log units) below it, and the stated range ends below it.
By their numbers in this assay, from the lowest: compound 2; then compounds 1 and 3 (each within the scatter of the next).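

In this assay the hydroxy in place of hydrogen on this aromatic carbon gives an 8.2-fold higher number from compound 2 to compound 3 (0.92 log units; beyond the scatter) and so, unlike the earlier pair of compounds, which differ in more than one place, shows this change on its own as a step beyond the scatter. The second new pair isolates the added chloro: a 1.4-fold higher number from compound 1 to compound 3 (0.14 log units; within the scatter) stays within the scatter, so with the new hydroxy in place, the chloro makes no clear difference to the number. No measured finding here explains why the added hydroxy is accompanied by this higher number.

As far as these compounds go, the hydroxy step is read only with the chloro present, so its size without the chloro remains open. From the compounds shown here alone, whether a methoxy or an amine on this same carbon would give a similar number also remains open.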